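The compounds below may be only part of what the source reports. "The series", "measured", "known", "first", "only" and "open" are said of these compounds alone.

Working notes on the series. Of the compounds shown here, two have numbers so far: compound 1 `COc1cc(C=C(C(=O)/C=C/c2cccc(OC)c2OC)C(=O)/C=C/c2cccc(OC)c2OC)ccc1O` and compound 2 `COc1cc(OC)c(/C=C/C(=O)C(=Cc2ccc(O)c(OC)c2)C(=O)/C=C/c2c(OC)cc(OC)cc2OC)c(OC)c1`. In a functional assay on SW480 cells (Homo sapiens) for antiproliferative activity, read by sulforhodamine B assay, with a stated time of 48 h (a higher number here means a weaker inhibitor, a lower number a stronger inhibitor), compound 1 gives 430 nM, and compound 2 gives 1490 nM. Compound 2 therefore holds the higher of the two numbers, making it the weaker inhibitor by a gap beyond the scatter. The two structures differ in more than one place, so this gap cannot be assigned to any single change.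

Compound 3 `COc1cc(OC)c(/C=C/C(=O)C(=Cc2cc(OC)c(O)c(OC)c2)C(=O)/C=C/c2c(OC)cc(OC)cc2OC)c(OC)c1` follows from compound 2 by one change, (methoxy in place of hydrogen on an aromatic carbon). This is methoxy in place of hydrogen on an aromatic carbon, ortho to a hydroxy group, and it turns 4-hydroxy-3-methoxyphenyl into 4-hydroxy-3,5-dimethoxyphenyl.

Within the data shown here, no measured pair isolates this change, so the data give no direct guide to its size or direction. The working expectation is therefore modest, leaning slightly towards a lower number but staying within the scatter. The expected step is a 1.4-fold lower number from compound 2 to compound 3 (0.13 log units; within the scatter). Compound 3 is estimated at 1100 nM, with an expected range of 450 nM to 2800 nM.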

Compound 3, half-maximal inhibitory concentration: 980 nM
Compound 3: the middle estimate sits 1.1-fold (0.05 log units) above what was measured, within the range that was stated.
By their numbers in this assay, from the lowest: compound 1; then compounds 3 and 2 (each within the scatter of the next).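

Among these compounds, this is the first reading at this position: in this assay, methoxy in place of hydrogen on an aromatic carbon, ortho to a hydroxy group, gives a 1.5-fold lower number from compound 2 to compound 3 (0.18 log units; within the scatter) and so cannot be told apart from no effect. The position therefore accepts a methoxy group, with its two heavy atoms and one hydrogen-bond acceptor, without a measurable shift in the number, and the hydroxy group stays in place in both compounds. Nothing measured here offers an explanation for this result.

A single group at this position leaves open whether the same flat reading would hold for a chlorine atom, an amine or a longer chain such as ethoxy in place of the methoxy group, or whether a larger group would move the number beyond the scatter. From the compounds shown here alone, whether the step carries over to the background of compound 1, and what happens when the neighbouring hydroxy group itself is replaced by a methoxy group, also stays open.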